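Three stereoisomers of one sulfoxide at the muscarinic receptor

This account rests on a few compounds, and the source may have more. Where it says the series, first, only, none or still open, it means among the compounds named here.

The series consists of three compounds that share every atom and bond and differ only in the configuration drawn at their stereocentres. Compound 1 `C[C@@H]1O[C@H]([C@H]2CCCN2C)C[S@@+]1[O-]` was measured in an assay on CHO cells for binding affinity to muscarinic acetylcholine receptor M5 (Homo sapiens); on this read-out lower numbers stand for stronger inhibition and higher numbers for weaker inhibition. In this assay compound 1 gives < 100000 nM, which is a limit of the assay and not a number. Compound 2 `C[C@H]1O[C@@H]([C@H]2CCCN2C)C[S@+]1[O-]` is its stereoisomer. In this assay compound 2 gives < 100000 nM, again a limit and not a number. The step that the two limits leave unreadable from compound 1 to compound 2 therefore cannot be read, as the limit of < 100000 nM in this assay, at which 2 of the 2 values shown sit, makes clear, even though the fact that compounds 1 and 2 differ only in the configuration as drawn shows exactly what changes between them.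

Compound 3 `C[C@@H]1O[C@H]([C@@H]2CCCN2C)C[S@+]1[O-]` has not been measured in this assay. It differs from compound 2 only in configuration: the two compounds have the same atoms and bonds and differ only in configuration as drawn: 3 of 4 stereo elements differ; a stereocentre at a saturated ring carbon is drawn S in compound 2 and R in compound 3; a stereocentre at a saturated ring carbon is drawn S in compound 2 and R in compound 3; a stereocentre at a saturated ring carbon is drawn R in compound 2 and S in compound 3. For the measured compounds named here, the one measured step is unreadable in size, so no direction beyond the scatter can be expected for the step from compound 2 to compound 3; the estimate is a step that the limit leaves unreadable from compound 2 to compound 3. Compound 3 is accordingly expected to give 30000 nM in this assay, within a range of 3000 nM to 100000 nM, with a fair chance that only a limit is reported.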

Compound 3, inhibition constant: < 100000 nM
Compound 3: no number, only a limit; the forecaster's own chance of this, stated with the estimate: 65%; the middle value is on the limit's open side.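

The steps among compound 1, compound 2 and compound 3 cannot be read in this assay, because all three compounds give a limit of the assay and not a number: the limit of < 100000 nM in this assay, at which 3 of the 3 values shown sit. The compounds shown leave open whether changing the drawn configuration at the ring carbons or at the sulfur alters binding affinity at all, and by how much.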